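The source may report more compounds than this note shows. Statements on the series, on what has been measured and on what is new or still open speak of the compounds shown alone.

Compounds measured in a functional assay on Huh-7 cells (Homo sapiens) for inhibition, read by MTT assay, with a stated time of 48 h; a lower number here means a stronger inhibitor, a higher number a weaker inhibitor:

Compound 1 `Cc1nnsc1CO/N=C/c1c(C)nn(C)c1Oc1ccc(C(C)(C)C)cc1` — > 50000 nM, a limit of the assay.
Compound 2 `CCCc1nnsc1CO/N=C/c1c(C)nn(C)c1Oc1ccc(Cl)cc1` — > 50000 nM, a limit of the assay.
Compound 3 `CCCc1nnsc1CO/N=C/c1c(C)nn(C)c1Oc1ccccc1C` — > 50000 nM, a limit of the assay.

Compound 3 stands on no number of its own in this assay, only on a limit, and the two other compounds likewise show only limits. For the measured compounds named here, the one measured step that touches compound 3, a step that the two limits leave unreadable from compound 2 to compound 3, cannot be read because both ends are limits. That leaves nothing on which a direction or a size could be built, since (the limit of > 50000 nM in this assay, at which 3 of the 3 values shown sit).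

Compound 4 `CCCc1nnsc1CO/N=C/c1c(C)nn(C)c1Cl` differs from compound 3 in one place: chloro in place of 2-methylphenoxy on an aromatic carbon. Going by the values given here, no measured step bears on this change, so no shift beyond the usual scatter can be expected from the data on hand, and the most that can be said is that the shared core has so far given no readable number in this assay. Compound 4 is therefore expected to sit near 50000 nM, within 15000 nM to 150000 nM, with a step estimated as a number no higher from compound 3 to compound 4 (the limit leaves the size open), and it is more likely than not that the assay again reports only a limit.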

Compound 4, half-maximal inhibitory concentration: > 50000 nM
Compound 4 gave a limit, no number; the forecaster's own chance of this, stated with the estimate: 70%; the middle value lies on the limit itself.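

In this assay compound 4 gives > 50000 nM, a limit of the assay. The steps from compound 2 and compound 3 to compound 4 cannot be read, since both ends of each are limits: the limit of > 50000 nM in this assay, at which 4 of the 4 values shown sit.

The compounds shown leave open whether any change to the shared core would give a readable number in this assay.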